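Carbonyl substituent exchange in a cytotoxicity series

A few compounds are considered here, and "the series" means these few. Any claim that something is new, unique, unknown or untested is made for them only; others in the source may bear on it.

Of the compounds shown here, two have been measured in a functional assay on WI-38 VA13 cells (Homo sapiens) for cytotoxicity; a higher number here means that more compound is needed for the effect, a lower number that less compound is needed. Compound 1 `CNc1c(C(=O)c2ccccc2)sc2nc(-c3cccs3)ccc12` gives 0.42 ug/mL; compound 2 `CC(C)(C)C(=O)c1sc2nc(-c3cccs3)ccc2c1N` gives 0.57 ug/mL, so compound 2 stands alongside compound 1, the two numbers within the scatter of each other. Compound 3 `Nc1c(C(=O)c2ccc(F)cc2)sc2nc(-c3cccs3)ccc12` is not yet measured. It differs from compound 2 by 4-fluorophenyl in place of tert-butyl on a carbonyl carbon. Since compound 1 already carries a benzoyl-type group and its value 0.42 ug/mL sits within the scatter of compound 2, no step beyond the scatter is expected in this assay. For compound 3 the estimated value is 0.45 ug/mL (range 0.2 ug/mL to 1 ug/mL), an expected step of a 1.3-fold lower number from compound 2 to compound 3 (0.10 log units; within the scatter).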

Compound 3, half-maximal effective concentration: 1.8 ug/mL
Compound 3: the middle estimate sits 4.0-fold (0.60 log units) below what was measured; the whole stated range lies below it.
By their numbers in this assay, from the lowest: compounds 1 and 2 (each within the scatter of the next); then compound 3.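

In this assay, 4-fluorophenyl in place of tert-butyl on a carbonyl carbon gives a 3.2-fold higher number from compound 2 to compound 3 (0.50 log units; beyond the scatter). For the compounds shown here, the number at this position therefore depends on the group carried there, which the earlier compounds, within the scatter of each other, could not show. The data shown give no reason for this step.

Still open, from the compounds shown here alone, is whether the step follows the six-membered aromatic ring or the fluorine it carries. Cyclohexyl or unsubstituted phenyl on the same carbonyl carbon, with the rest of compound 3 unchanged, would separate these two readings.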